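Swapping a ring halogen for methoxy on a shared core

The source may report more compounds than this note shows. Statements on the series, on what has been measured and on what is new or still open speak of the compounds shown alone.

Compound 1, `COC(=O)[C@@]1(C)CC[C@@H]2C3=C1CC[C@@H](C)[C@]3(C)C[C@@H]1c3cc(Br)ccc3N[C@H]21`, gives 25000 nM in a functional assay on HeLa cells (Homo sapiens) for inhibition, read by sulforhodamine B assay, with a stated time of 48 h; on this read-out lower numbers stand for stronger inhibition of growth and higher numbers for weaker inhibition of growth.
Compound 2, `COC(=O)[C@@]1(C)CC[C@@H]2C3=C1CC[C@@H](C)[C@]3(C)C[C@@H]1c3cc(F)ccc3N[C@H]21`, gives 20000 nM in this assay.

For the measured compounds named here, of the two numbers measured so far, compound 2 shows the lower one, yet the gap to compound 1 is small: a 1.3-fold lower number from compound 1 to compound 2 (0.10 log units; within the scatter). Going by the values given here, that exchange of bromo for fluoro on an aromatic carbon is the only comparison available, and it did not move the number beyond the scatter.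

Compound 3, `COC(=O)[C@@]1(C)CC[C@@H]2C3=C1CC[C@@H](C)[C@]3(C)C[C@@H]1c3cc(OC)ccc3N[C@H]21`, differs from compound 2 on an aromatic carbon of the shared core: methoxy in place of fluoro on an aromatic carbon. Among the compounds with values here, no measured pair shows how a methoxy group behaves here. Within the data shown here, the one step that bears on it, from compound 1 to compound 2, stayed within the scatter, so for compound 3 the number in this assay is expected to remain close to that of compound 2, with no change at the digits printed from compound 2 to compound 3 (within the scatter) as the expected step. Compound 3 is therefore estimated at 20000 nM, with a range from 7000 nM to 60000 nM.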

Compound 3, concentration for 50% growth inhibition: 20000 nM
The estimate for compound 3 equals the measured number at the digits printed; the measured number falls inside the stated range.
By their numbers in this assay, from the lowest: compounds 2, 3 and 1 (each within the scatter of the next).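

Methoxy differs from both halogens: it brings two heavy atoms and a hydrogen-bond acceptor, where fluoro has one heavy atom and no acceptor. Even so, this assay shows no change at the digits printed from compound 2 to compound 3 (within the scatter) and a 1.3-fold lower number from compound 1 to compound 3 (0.10 log units; within the scatter), so this aromatic carbon has now carried a group other than a halogen without the number moving beyond the scatter. Nothing measured here explains why these three groups give numbers so close together.

Still open, going by these compounds, is whether an amine, a carboxylic acid or a longer chain such as butoxy on this same carbon would shift the number beyond the scatter. With only fluoro, bromo and methoxy shown, the results say nothing about the other positions of the shared core, including the methyl ester.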